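The source may hold more compounds than are shown below. What is called first, only, known or untested is meant among the compounds shown, and "the series" means these compounds.

Measured compounds:
- Compound 1, `Nc1ccccc1NC(=O)c1ccc(CSC(=S)N2CCN(Cc3ccccn3)CC2)cc1`: 14.2%
- Compound 2, `N#Cc1ccc(N2CCN(C(=S)SCc3ccc(C(=O)Nc4ccccc4N)cc3)CC2)cc1`: 71.6%
- Compound 3, `Nc1ccccc1NC(=O)c1ccc(CSC(=S)N2CCN(c3ncccn3)CC2)cc1`: 52.2%

All three share one core and differ only in the group carried on an amine nitrogen in a ring. In a functional assay on HeLa cells (Homo sapiens) for antiproliferative activity, read by CCK-8 assay, with a stated time of 72 h, tested at 2 uM (a higher number here means a stronger effect of the compound at the concentration tested, a lower number a weaker effect), compound 3 stands second highest of the three numbers: it lies a number 19.4 percentage points lower from compound 2 to compound 3 (beyond the scatter) and a number 38 percentage points higher from compound 1 to compound 3 (beyond the scatter). The compound still to be measured is compound 4, `Nc1ccccc1NC(=O)c1ccc(CSC(=S)N2CCN(c3ccccc3F)CC2)cc1`, with 2-fluorophenyl in place of pyrimidin-2-yl on an amine nitrogen in a ring. The step that bears most on this change is the swap of one directly attached aromatic ring for another, a number 19.4 percentage points lower from compound 2 to compound 3 (beyond the scatter), which was modest. The two larger steps, a number 57.4 percentage points higher from compound 1 to compound 2 (beyond the scatter) and a number 38 percentage points higher from compound 1 to compound 3 (beyond the scatter), both replaced a ring joined through a single carbon with a ring attached directly, so they speak for compound 4 keeping a number well above compound 1. Compound 4 is therefore expected to move by no more than a modest step from compound 3, a number 7.8 percentage points higher from compound 3 to compound 4 (within the scatter), with the direction open. The estimate for compound 4 in this assay is 60%, in a range from 40% to 78%.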

Compound 4, a percentage reported as inhibition, at one concentration (the size of the read-out at that concentration, not a potency): 17.5%
Compound 4: middle estimate off by 42.5 percentage points, on the high side; measured number below the stated range.
By their numbers in this assay, from the lowest: compounds 1 and 4 (each within the scatter of the next); then compound 3; then compound 2.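

In this assay, a ring attached directly to this nitrogen is not enough to keep the number high: the swap of pyrimidin-2-yl for 2-fluorophenyl gives a large drop (a number 34.7 percentage points lower from compound 3 to compound 4 (beyond the scatter)), and the swap of 4-cyanophenyl for 2-fluorophenyl gives a larger one (a number 54.1 percentage points lower from compound 2 to compound 4 (beyond the scatter)). The earlier compounds shown here suggested that direct attachment set the level, but compound 4 goes against this, with the step from the ring joined through a single carbon staying small (a number 3.3 percentage points higher from compound 1 to compound 4 (within the scatter)), so which ring is attached matters as well as how it is joined. No measurement at hand explains these differences.

On these data alone, it remains open whether the fluorine or the carbon-only ring goes with the low number of compound 4, though compound 2 also carries a carbon-only ring and stands high. A plain phenyl group would help separate the two, and a pyridin-2-yl group would show what a single ring nitrogen does here.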